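Working notes: replacing the carbamoylamino arm on the shared core

The source may report more compounds than this note shows. Statements on the series, on what has been measured and on what is new or still open speak of the compounds shown alone.

In a functional assay on CCRF-CEM cells (Homo sapiens) for inhibition, read by MTT assay, with a stated time of 72 h (on this read-out lower numbers stand for stronger inhibition and higher numbers for weaker inhibition), compound 1 `COc1cc(NC(C)CCCNC(=O)Nc2ccc(F)cc2)c2ncccc2c1` gives 26000 nM, compound 2 `COc1cc(NC(C)CCCNC(=O)NNC(=O)Nc2ccc(Br)cc2)c2ncccc2c1` gives 110000 nM and compound 3 `COc1cc(NC(C)CCCNC(=O)NNC(=O)Nc2cccc(Cl)c2)c2ncccc2c1` gives 81000 nM. Compound 3 therefore sits level with compound 2, the measured difference being a 1.4-fold lower number from compound 2 to compound 3 (0.13 log units; within the scatter). It stands clear of compound 1, with a 3.1-fold higher number from compound 1 to compound 3 (0.49 log units; beyond the scatter). The comparison with compound 2 runs the same way, with a 4.2-fold higher number from compound 1 to compound 2 (0.63 log units; beyond the scatter).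

Compound 4 `COc1cc(NC(C)CCCNC(=O)Nc2ccc(O)cc2)c2ncccc2c1` carries 4-hydroxyphenyl in place of ((3-chlorophenyl)carbamoyl)amino on an amide-type nitrogen. This runs opposite to the two modest steps out of compound 1, which are the closest guide, since compound 4 keeps the aryl directly on that nitrogen, as compound 1 does. Within the data shown here, no measured compound shows what the 4-hydroxyphenyl group itself contributes, so the range stays wide.

The step expected in this assay is a 3.4-fold lower number from compound 3 to compound 4 (0.53 log units; beyond the scatter), similar in size to those two steps but in the opposite direction. The estimate for compound 4 is 24000 nM, with an expected range of 9000 nM to 65000 nM.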

Compound 4, half-maximal inhibitory concentration: 23000 nM
Estimate against measurement, compound 4: 1.0-fold (0.02 log units) above, within the range that was stated.
By their numbers in this assay, from the lowest: compounds 4 and 1 (each within the scatter of the next); then compounds 3 and 2 (each within the scatter of the next).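

With the aryl group placed directly on the amide-type nitrogen, the number in this assay drops below those of both carbamoylamino compounds (a 3.5-fold lower number from compound 3 to compound 4 (0.55 log units; beyond the scatter)) (a 4.8-fold lower number from compound 2 to compound 4 (0.68 log units; beyond the scatter)), so the lower numbers are not confined to the 4-fluorophenyl group of compound 1. Hydroxy in place of fluoro on an aromatic carbon gives no separable difference (a 1.1-fold lower number from compound 1 to compound 4 (0.05 log units; within the scatter)), so these two groups cannot be told apart in this assay. No available evidence explains these differences.

Compounds 2 and 3 differ from compounds 1 and 4 in both the arm and the ring substituent, so the contribution of the carbamoylamino arm alone cannot be read. Going by these compounds, it also remains open whether an amine or a carboxylic acid on that aromatic carbon would stay within the scatter of compound 1.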